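Aryl swap on a shared core: compound 4 expected

This account rests on a few compounds, and the source may have more. Where it says the series, first, only, none or still open, it means among the compounds named here.

Three compounds share one core and differ only in the aryl group on a double-bonded chain carbon bound to an aromatic carbon. In a functional assay on MOLT-4 cells (Homo sapiens) for cytotoxicity, read by CCK-8 assay, with a stated time of 72 h (on this read-out higher numbers stand for weaker inhibition and lower numbers for stronger inhibition), compound 1 `C=CCn1c(=O)/c(=C\c2cccc(Cl)c2)[nH]c(=O)/c1=C\c1ccccc1OC` gives 4900 nM and compound 2 `C=CCn1c(=O)/c(=C\c2cccc(Br)c2)[nH]c(=O)/c1=C\c1ccccc1OC` gives 5000 nM, with a 1.0-fold higher number from compound 1 to compound 2 (0.01 log units; within the scatter). Compound 3 `C=CCn1c(=O)/c(=C\c2cc(F)ccc2C)[nH]c(=O)/c1=C\c1ccccc1OC` gives 3800 nM, the lowest of the three numbers, though both a 1.3-fold lower number from compound 1 to compound 3 (0.11 log units; within the scatter) and a 1.3-fold lower number from compound 2 to compound 3 (0.12 log units; within the scatter) sit within the scatter. Compound 4 `C=CCn1c(=O)/c(=C\c2cccc(C)c2)[nH]c(=O)/c1=C\c1ccccc1OC` carries 3-methylphenyl in place of 5-fluoro-2-methylphenyl on a double-bonded chain carbon bound to an aromatic carbon. Since every exchange of this aryl group so far left this assay essentially unchanged, no step beyond the scatter is expected for compound 4, with a 1.2-fold higher number from compound 3 to compound 4 (0.07 log units; within the scatter) as the estimate. Compound 4 is therefore estimated at 4500 nM, within a range of 2000 nM to 10000 nM.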

Compound 4, half-maximal inhibitory concentration: 16000 nM
For compound 4 the middle estimate is 3.6-fold (0.55 log units) below the measured one; the whole stated range lies below it.
By their numbers in this assay, from the lowest: compounds 3, 1 and 2 (each within the scatter of the next); then compound 4.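

In this assay this position proves not to be indifferent: a 4.2-fold higher number from compound 3 to compound 4 (0.62 log units; beyond the scatter) accompanies the change to 3-methylphenyl on the double-bonded chain carbon. Methyl in place of bromo on an aromatic carbon gives a 3.2-fold higher number from compound 2 to compound 4 (0.51 log units; beyond the scatter) and methyl in place of chloro gives a 3.3-fold higher number from compound 1 to compound 4 (0.51 log units; beyond the scatter) as well, so compound 4 alone stands apart from compounds 1, 2 and 3. Nothing available bears on the cause of these steps.

The compounds shown leave open whether a nitrile or an amine on this aryl group would follow compound 4 or stay with compounds 1, 2 and 3.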